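Trading 4-fluorophenyl for 3-methylphenyl: a small step expected

A few compounds are considered here, and "the series" means these few. Any claim that something is new, unique, unknown or untested is made for them only; others in the source may bear on it.

Two compounds have values in a functional assay on K562 cells (Homo sapiens) for antiproliferative activity, read by MTT assay; on this read-out higher numbers stand for weaker inhibition and lower numbers for stronger inhibition. Compound 1 (`O=C(CCCCCNC(=S)NN=C(c1ccccc1)c1ccccc1)NO`) gives 3810 nM, and compound 2 (`C/C(=N\NC(=S)NCCCCCC(=O)NO)c1ccc(F)cc1`) gives 1890 nM. These two values lie within the scatter of each other, so compound 2 stands level with compound 1 and the numbers do not rank them.

Compound 3 (`C/C(=N\NC(=S)NCCCCCC(=O)NO)c1cccc(C)c1`) has no value yet. It differs from compound 2 in one place: 3-methylphenyl in place of 4-fluorophenyl on a carbon with a double bond to nitrogen. The change puts 3-methylphenyl in place of 4-fluorophenyl on a carbon with a double bond to nitrogen. Among the compounds with values here, the data contain no measured step for this change, so the expectation rests on little. Within the data shown here, with only two values available, no step beyond the scatter is expected in this assay, in either direction, and the estimate stays close to compound 2 at 1890 nM. The estimated step, a 1.1-fold higher number from compound 2 to compound 3 (0.02 log units; within the scatter), is expected to remain within the scatter. For compound 3 the estimate is 2000 nM, with an expected range of 900 nM to 4500 nM.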

Compound 3, half-maximal inhibitory concentration: 3840 nM
The estimate for compound 3 lay 1.9-fold (0.28 log units) below the measured number, within the range that was stated.
By their numbers in this assay, from the lowest: compounds 2, 1 and 3 (each within the scatter of the next, the first and the last beyond it).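

In this assay, trading 4-fluorophenyl for 3-methylphenyl on a carbon with a double bond to nitrogen gives a 2.0-fold higher number from compound 2 to compound 3 (0.31 log units; beyond the scatter), a modest step and the first one measured at this position. It shows that this position is not indifferent to the exact aromatic group: the two groups match in heavy-atom count, each holds one six-membered aromatic ring of carbon only, and neither carries a hydrogen-bond donor, a hydrogen-bond acceptor or a net charge, yet compound 2 inhibits more strongly than compound 3. Within the data shown here, nothing in the data accounts for this difference, and the single pair cannot say whether it belongs to the loss of fluorine, the gain of methyl or the different place of the substituent on the ring.

The compounds shown therefore leave open whether this step would hold for other groups at the same position or is particular to this pair. Also open, going by these compounds, is how an amine or a carboxylic acid would fare in place of either group on this carbon, and whether a step of this size would recur in another assay.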